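Removing the Aryl Substituent: What Compound 3 Might Show

This account rests on a few compounds, and the source may have more. Where it says the series, first, only, none or still open, it means among the compounds named here.

Compound 2 `Cc1nc2c3ccccc3ccc2c2nc3c(ccc4ccccc43)c(-c3cc(O)nc4ccccc34)c12` gives the lowest of the two numbers measured in a functional assay on HeLa cells (Homo sapiens) for cytotoxicity, read by MTT assay, with a stated time of 48 h (on this read-out lower numbers stand for stronger inhibition and higher numbers for weaker inhibition), namely 4880 nM. Its nearest comparator, compound 1 `Cc1nc2c3ccccc3ccc2c2nc3c(ccc4ccccc43)c(-c3cccc4ccccc34)c12`, gives 14900 nM, and the step of a 3.1-fold lower number from compound 1 to compound 2 (0.48 log units; beyond the scatter) came from swapping one aryl group for another. Compound 3 `Cc1nc2c3ccccc3ccc2c2nc3c(ccc4ccccc43)c(C)c12` carries a smaller change: methyl in place of 2-hydroxyquinolin-4-yl on an aromatic carbon. Among the measured compounds shown here, no measured step bears directly on exchanging an aryl for methyl, so the estimate rests on compound 1's value 14900 nM as the weaker reference. Compound 3 is therefore expected to give a higher number, estimated at 15000 nM with a range from 5000 nM to 45000 nM, a step of a 3.1-fold higher number from compound 2 to compound 3 (0.49 log units; beyond the scatter).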

Compound 3, half-maximal inhibitory concentration: > 80000 nM
Compound 3: no number, only a limit; the forecaster's own chance of this, stated with the estimate: 10%; middle value at least 5.3-fold (0.72 log units) away from the limit.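

In this assay, compound 3 gives > 80000 nM, which is a limit of the assay and not a number. Among the compounds shown here, the earlier compounds compared only two ring-bearing groups at this aromatic carbon, and both gave measured values; replacing either with methyl gives an at least 16-fold higher number from compound 2 to compound 3 (1.21 log units; beyond the scatter) and an at least 5.3-fold higher number from compound 1 to compound 3 (0.72 log units; beyond the scatter). Among these compounds, then, only the two with a ring-bearing group here reach a number in this assay. From the compounds shown here alone, what an amine or a longer chain would give at this position remains open, as does the result of a phenyl ring there.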